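This account rests on a few compounds, and the source may have more. Where it says the series, first, only, none or still open, it means among the compounds named here.

Measured so far:
- Compound 1 `COc1ccc(/C=C\c2cccc3c2oc(=O)n3C)cc1`: > 50000 nM (a limit)
- Compound 2 `COc1cc(/C=C\c2cccc3c2oc(=O)n3C)cc(OC)c1OC`: 10300 nM

Within the data shown here, in a functional assay on EA.hy 926 cells (Homo sapiens) for inhibition, read by MTT assay, with a stated time of 72 h (on this read-out higher numbers stand for weaker inhibition and lower numbers for stronger inhibition), compound 2 gives 10300 nM, the only actual number so far. Compound 1 reads > 50000 nM, which is a limit and not a number.

Compound 3 `COc1cc(/C=C\c2cccc3c2oc(=O)n3C)cc(OC)c1` has hydrogen in place of methoxy on an aromatic carbon, ortho to two methoxy groups and para to a large group (hydrogen in place of methoxy on an aromatic carbon). Among the measured compounds shown here, no measured pair shows this change, so only a moderate move toward weaker inhibition is expected, and a limit reading is possible. The expected change is a 2.7-fold higher number from compound 2 to compound 3 (0.43 log units; beyond the scatter). For compound 3 the estimated value is 28000 nM, within an expected range of 10000 nM to 80000 nM.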

Compound 3, half-maximal inhibitory concentration: 9530 nM
Beside the measured number, compound 3's estimate is 2.9-fold (0.47 log units) above it; measured number below the stated range.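

Replacing the methoxy group with hydrogen, on the aromatic carbon ortho to two methoxy groups and para to a large group, gives a 1.1-fold lower number from compound 2 to compound 3 (0.03 log units; within the scatter) in this assay. Among these compounds, this is the first direct reading of this position, and on this measure the methoxy group there is not needed to keep the inhibition seen with compound 2. No measurement shown gives a reason for this result.

From the compounds shown here alone, whether an amine, a hydroxyl group or a longer chain at this position would change the reading remains open. So does the part played by each remaining methoxy group, as no pair shown changes either one alone.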